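The source may report more compounds than this note shows. Statements on the series, on what has been measured and on what is new or still open speak of the compounds shown alone.

Measured so far, in a functional assay (aorta) with Rattus norvegicus as the target; a lower number here means a stronger inhibitor, a higher number a weaker inhibitor: compound 1 `CCO/C(O)=C1\C(COCCn2ccnn2)=NC(C)=C(C(=O)OC)C1c1cccc(Cl)c1Cl` gives 5.01 nM; compound 2 `CCO/C(O)=C1\C(COCCN2CC(=O)N=C2N)=NC(C)=C(C(=O)OC)C1c1ccccc1Cl` gives 20 nM; compound 3 `CCO/C(O)=C1\C(COCCN2CC(=O)NC2=O)=NC(C)=C(C(=O)OC)C1c1cccc(Cl)c1Cl` gives 3.16 nM.

Compound 2 stands at the highest number of the three in this assay; its gap to compound 1 and its larger gap to compound 3 both lie beyond the scatter, so compound 2 is the weakest inhibitor among the measured set. Compound 4 `CCO/C(O)=C1\C(COCCN2CC(=O)N(C)C2=O)=NC(C)=C(C(=O)OC)C1c1ccccc1Cl` differs from compound 2 in one place: a group of 8 heavy atoms (4 carbon, 2 nitrogen, 2 oxygen; one five-membered non-aromatic ring with 2 hetero atoms) in place of a group of 7 heavy atoms (3 carbon, 3 nitrogen, 1 oxygen; one five-membered non-aromatic ring with 2 hetero atoms), on a saturated chain carbon, two bonds along the chain from an oxygen on a saturated carbon. For the measured compounds named here, the one measured step that bears on such an exchange of the five-membered ring on the chain is a 1.6-fold lower number from compound 1 to compound 3 (0.20 log units; within the scatter), where the ring was also swapped for a dioxoimidazolidinyl group and the number moved only a little, toward a lower value. That exchange, however, involved a different departing ring and a different aryl group than in compound 2, so it is only a loose guide. Taking it as the best available indication, the step of a 1.7-fold lower number from compound 2 to compound 4 (0.22 log units; within the scatter) is expected to be small and, if anything, toward a lower number. Compound 4 is therefore estimated at 12 nM, with a plausible range from 3 nM to 50 nM.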

Compound 4, half-maximal inhibitory concentration: 25.1 nM
Estimate against measurement, compound 4: 2.1-fold (0.32 log units) below, within the range that was stated.
By their numbers in this assay, from the lowest: compounds 3 and 1 (each within the scatter of the next); then compounds 2 and 4 (each within the scatter of the next).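

In this assay, a 1.3-fold higher number from compound 2 to compound 4 (0.10 log units; within the scatter), so this second exchange of the five-membered ring at the saturated chain carbon, like a 1.6-fold lower number from compound 1 to compound 3 (0.20 log units; within the scatter), gives no readable change in the number. The new step adds that the entering 3-methyl-2,4-dioxoimidazolidin-1-yl has 0 hydrogen-bond donors and 2 acceptors where the leaving group has 1 donor and 3 acceptors, and these different counts come with no difference beyond the scatter. No measurement shown explains this result.

The compounds shown leave open whether a simple amine or a carboxylic acid in place of the ring, or a longer chain, would move the number beyond the scatter. They also leave open what the methyl on the ring contributes alone, since no pair shown differs only by that methyl.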